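Aryl-amine variation on a shared quinazoline-free described core

A few compounds are considered here, and "the series" means these few. Any claim that something is new, unique, unknown or untested is made for them only; others in the source may bear on it.

Measured compounds:
- compound 1 `COc1cc2ncnc(Nc3cccc(Cl)c3)c2cc1OCCCCC(=O)Nc1ccc(S(N)(=O)=O)cc1`: 30400 nM in a functional assay on A-431 cells (Homo sapiens) for antiproliferative activity, read by MTT assay, with a stated time of 72 h; on this read-out higher numbers stand for weaker inhibition and lower numbers for stronger inhibition
- compound 2 `COc1cc2ncnc(Nc3ccc(F)cc3)c2cc1OCCCCC(=O)Nc1ccc(S(N)(=O)=O)cc1`: 18600 nM in this assay
- compound 3 `COc1cc2ncnc(Nc3ccc(Br)cc3)c2cc1OCCCCC(=O)Nc1ccc(S(N)(=O)=O)cc1`: 6570 nM in this assay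

Compound 3 gives the lowest number of the three. Its nearest neighbour is compound 2, with a 2.8-fold lower number from compound 2 to compound 3 (0.45 log units; beyond the scatter) separating them, and compound 1 lies furthest, with a 4.6-fold lower number from compound 1 to compound 3 (0.67 log units; beyond the scatter). The step of a 1.6-fold lower number from compound 1 to compound 2 (0.21 log units; within the scatter) is the only one of the three that stays within the scatter.

Compound 4 `COc1ccc(Nc2ncnc3cc(OC)c(OCCCCC(=O)Nc4ccc(S(N)(=O)=O)cc4)cc23)cc1OC` is not yet measured in this assay. Relative to compound 3 the change is 3,4-dimethoxyphenyl in place of 4-bromophenyl on a nitrogen on an aromatic ring. Among the compounds with values here, none of the measured steps covers this change: all three vary a halogen on the phenyl attached to that nitrogen, while compound 4 carries no halogen there and two methoxy groups instead. The halogen steps at this position spanned from within the scatter up to modest, so the position is responsive, but the direction for a dimethoxyphenyl cannot be read from the shown data.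

Within the data shown here, with no bearing step, the estimate for compound 4 is set near the measured spread, as 15000 nM with a range from 4000 nM to 60000 nM. This estimate corresponds to an expected step of a 2.3-fold higher number from compound 3 to compound 4 (0.36 log units; beyond the scatter), with wide uncertainty in either direction.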

Compound 4, half-maximal inhibitory concentration: 35400 nM
The estimate for compound 4 lay 2.4-fold (0.37 log units) below the measured number; measured number inside the range.
By their numbers in this assay, from the lowest: compound 3; then compounds 2, 1 and 4 (each within the scatter of the next).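

Among the aryl groups on this nitrogen, the first without a halogen, 3,4-dimethoxyphenyl, loses the advantage held by 4-bromophenyl in this assay (a 5.4-fold higher number from compound 3 to compound 4 (0.73 log units; beyond the scatter)), which makes compound 3 the strongest of the four, with steps beyond the scatter to each of the others. The dimethoxy group does not separate from either of the other two halogen-bearing compounds, since both steps stay within the scatter (a 1.9-fold higher number from compound 2 to compound 4 (0.28 log units; within the scatter); a 1.2-fold higher number from compound 1 to compound 4 (0.07 log units; within the scatter)), so at this position only the 4-bromophenyl group stands apart, and two methoxy groups in place of a halogen neither add to nor take from the level set by compounds 1 and 2. No supporting measurement bears on why this group behaves as it does.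

Still open, on these data alone, is whether the low number of compound 3 belongs to the bromo group alone, or whether a phenyl carrying a single methoxy group, an amine or a carboxylic acid would also reach it. Also open, as far as these compounds go, is whether the same order of aryl groups would hold with a shorter or longer chain linking the core to the sulfonamide-bearing amide.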